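A few compounds are considered here, and "the series" means these few. Any claim that something is new, unique, unknown or untested is made for them only; others in the source may bear on it.

In a physicochemical assay for solubility, read by LC-MS, in phosphate buffer, with a stated time of 24 h, at pH 7.4 (on this read-out higher numbers stand for higher solubility and lower numbers for lower solubility), compound 1 `O=C(Nc1ccccc1)c1cnc(NCc2c(F)ccc3c2CCO3)n2cnnc12` gives only a limit of the assay, < 1000 nM. Compound 3 `Cn1nccc1-c1cnc(NCc2c(F)ccc3c2CCO3)c2cn[nH]c(=O)c12` gives 2000 nM and compound 2 `Cc1ncccc1-c1cnc(NCc2c(F)ccc3c2CCO3)c2nn(CC#N)c(=O)n12` gives 4000 nM, two values that lie within the usual scatter of each other. Compound 4 `Cc1ncccc1-c1cnc(NCc2c(F)ccc3c2CCO3)c2cn[nH]c(=O)c12` has not yet been measured. It has 2-methylpyridin-3-yl in place of the 1-methyl-1H-pyrazol-5-yl of compound 3, on an aromatic carbon (2-methylpyridin-3-yl in place of 1-methyl-1H-pyrazol-5-yl on an aromatic carbon). Within the data shown here, no measured pair shows this change alone, but compound 2 carries the same 2-methylpyridin-3-yl group on another core and gives 4000 nM. A small upward move, within the scatter, is therefore expected, an estimated 1.5-fold higher number from compound 3 to compound 4 (0.18 log units; within the scatter). For compound 4 the expected value is 3000 nM, with an estimated range of 1000 nM to 8000 nM.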

Compound 4, solubility: < 2000 nM
Compound 4 ended at the assay's limit; the forecaster's own chance of this, stated with the estimate: 15%; middle value at least 1.5-fold (0.17 log units) away from the limit.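

In this assay, putting 2-methylpyridin-3-yl in place of 1-methyl-1H-pyrazol-5-yl on the shared core gives a number no higher from compound 3 to compound 4 (the limit leaves the size open). Among these compounds, this is the only direct comparison of the two groups on this aromatic carbon, and it shows no gain from the change. Compound 4 gives < 2000 nM, which is a limit of the assay and not a number.

From the compounds shown here alone, how large the step is therefore stays open, as does whether it would look the same on another core. Also open, going by these compounds, is what a small amine or a carboxylic acid on this aromatic carbon would give.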